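The source may report more compounds than this note shows. Statements on the series, on what has been measured and on what is new or still open speak of the compounds shown alone.

Compound 1 `O=C(O)/C=C/c1ccc(Cn2cccn2)cc1OCCc1ccc2ccccc2c1` gives 12 nM in an assay on CHO cells for displacement of a labelled ligand from prostaglandin E2 receptor EP3 subtype (Mus musculus), read by scintillation counting (a higher number here means a weaker inhibitor, a lower number a stronger inhibitor), the lowest of the two numbers recorded here, while compound 2 `O=C(O)/C=C/c1ccc(Cc2ccccc2)cc1OCCc1ccc2ccccc2c1` gives 130 nM. For the measured compounds named here, the one measured step, an 11-fold higher number from compound 1 to compound 2 (1.03 log units; beyond the scatter), concerns a different part of the molecule and does not bear on the present change. Compound 3 `O=C(O)C#Cc1ccc(Cn2cccn2)cc1OCCc1ccc2ccccc2c1` differs from compound 1 by 2-carboxyethynyl in place of 2-carboxyethenyl on an aromatic carbon. Going by the values given here, with no measured step touching this group, only a modest shift in this assay is expected, in either direction, and possibly none beyond the scatter. Compound 3 is therefore estimated at 30 nM, within 8 nM to 120 nM, which would mean an expected 2.5-fold higher number from compound 1 to compound 3 (0.40 log units; beyond the scatter).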

Compound 3, inhibition constant: 99 nM
The estimate for compound 3 lay 3.3-fold (0.52 log units) below the measured number; measured number inside the range.
By their numbers in this assay, from the lowest: compound 1; then compounds 3 and 2 (each within the scatter of the next).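

In this assay, 2-carboxyethynyl in place of 2-carboxyethenyl on this aromatic carbon weakens binding (an 8.3-fold higher number from compound 1 to compound 3 (0.92 log units; beyond the scatter)), a step beyond the scatter. For the compounds shown here, this is the first measured change at this position, and it shows that binding responds to the bond in this chain even though both groups have the same heavy atoms. Nothing measured explains this step. Still open, as far as these compounds go, is whether a saturated 2-carboxyethyl group, a primary amide or a longer chain ending in a carboxylic acid would match compound 1. Also open, from the compounds shown here alone, is whether the same change has a similar effect when phenyl replaces 1H-pyrazol-1-yl.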